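Ester variation on a shared core: from compound 3 to compound 4

This account rests on a few compounds, and the source may have more. Where it says the series, first, only, none or still open, it means among the compounds named here.

Compound 1, `C=C1CC[C@H]2[C@@](C)(CC[C@@H](OC(=O)c3cccnc3)[C@@]2(C)NC=O)[C@@H]1/C=C/C1=CCOC1=O`, in an assay for inhibition of hexokinase-2 (Homo sapiens), read by coupled enzyme assay, with a stated time of 10 min, in the presence of a further agent that is not named here (a lower number here means a stronger inhibitor, a higher number a weaker inhibitor), gives only a limit, > 50000 nM.
Compound 2, `C=C1CC[C@H]2[C@@](C)(CC[C@@H](OC(=O)[C@H](N)CC(C)C)[C@@]2(C)NC=O)[C@@H]1/C=C/C1=CCOC1=O`, in this assay also gives only a limit, > 50000 nM.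
Compound 3, `C=C1CC[C@H]2[C@@](C)(CC[C@@H](OC(=O)[C@H]3CCCN3)[C@@]2(C)NC=O)[C@@H]1/C=C/C1=CCOC1=O`, in this assay gives 26100 nM.

Going by the values given here, compound 3 therefore holds the only number among the three; the other two sit at the limit, (the limit of > 50000 nM in this assay, at which 2 of the 3 values shown sit). The step from compound 1 to compound 2 cannot be read, a step that the two limits leave unreadable from compound 1 to compound 2. The step of an at least 1.9-fold lower number from compound 1 to compound 3 (0.28 log units; that floor lies within the scatter) and the step of an at least 1.9-fold lower number from compound 2 to compound 3 (0.28 log units; that floor lies within the scatter) each have a floor that lies within the scatter, so no ordering among the three is secured.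

Compound 4, `C=C1CC[C@H]2[C@@](C)(CC[C@@H](OC(=O)CCCC[C@@H]3CCSS3)[C@@]2(C)NC=O)[C@@H]1/C=C/C1=CCOC1=O`, differs from compound 3 in one place: a group of 9 heavy atoms (7 carbon, 2 sulfur; one five-membered non-aromatic ring with 2 hetero atoms) in place of a group of 5 heavy atoms (4 carbon, 1 nitrogen; one five-membered non-aromatic ring with 1 hetero atom), on a carbonyl carbon. Among the compounds with values here, none of the measured steps contains the entering group, so the steps to compound 3 bear on it only by showing that a different ester on this carbonyl carbon returned a limit in both cases. With no shown step to support a number below that of compound 3, a step back toward the limit is expected, a 1.7-fold higher number from compound 3 to compound 4 (0.24 log units; within the scatter). Compound 4 is accordingly estimated at 45000 nM, with a range from 12000 nM to 200000 nM.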

Compound 4, half-maximal inhibitory concentration: > 50000 nM
Compound 4 was reported as a limit; the forecaster's own chance of this, stated with the estimate: 55%; at least 1.1-fold (0.04 log units) between middle value and limit.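

In this assay compound 4 gives only a limit, > 50000 nM. Placing the group with two sulfur atoms in its five-membered non-aromatic ring in place of pyrrolidin-2-yl, on the same carbonyl carbon, gives an at least 1.9-fold higher number from compound 3 to compound 4 (0.28 log units; that floor lies within the scatter), so this change adds a further ester to those without a number but secures no ordering against compound 3. The steps from compound 1 and from compound 2 to compound 4 cannot be read, and compound 3 remains the only one of the four with a number rather than a limit, with ester groups of quite different shape now ending at the same place:  the limit of > 50000 nM in this assay, at which 3 of the 4 values shown sit.

As far as these compounds go, it remains open whether pyrrolidin-2-yl truly sets compound 3 apart on this carbonyl carbon, or whether the four compounds differ only by scatter, and how far compounds 1, 2 and 4 lie past their limit. Also open, from the compounds shown here alone, is whether another ester group here, such as a piperidine ring, a primary amine on a longer chain or a carboxylic acid, would return a number at all, and whether that number would fall under that of compound 3.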